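Methoxy to trifluoromethyl on the aryl of compound 1

This account rests on a few compounds, and the source may have more. Where it says the series, first, only, none or still open, it means among the compounds named here.

Compound 1 `COc1ccc(-c2nc(CNc3ccc(C(=O)NO)cc3)n(-c3ccccc3)n2)cc1` is the reference of this series. In an assay on Sf9 cells for inhibition of protein deacetylase HDAC6 (Homo sapiens), read by fluorescence, with a stated time of 40 min, tested at 100 nM (a lower number here means less inhibition, a higher number more inhibition at the concentration tested (going by the name of the read-out)), compound 1 gives 77.6%, the highest of the three numbers measured. For the measured compounds named here, compound 2 `Nc1ccccc1NC(=O)c1ccc(NCc2nc(-c3ccccc3)nn2-c2ccccc2)cc1` gives 5% and compound 3 `NNC(=O)c1ccc(NCc2nc(-c3ccccc3)nn2-c2ccccc2)cc1` gives 10%; the only measured single-point step, a number 5 percentage points higher from compound 2 to compound 3 (within the scatter), concerns the amide-type nitrogen and stays within the scatter, so it says nothing about the aryl end of the core.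

Compound 4 `O=C(NO)c1ccc(NCc2nc(-c3ccc(C(F)(F)F)cc3)nn2-c2ccccc2)cc1` differs from compound 1 in one place: trifluoromethyl in place of methoxy on an aromatic carbon. Going by the values given here, no measured pair shows the change from 4-methoxyphenyl to 4-(trifluoromethyl)phenyl, and the hydroxamic acid of compound 1, which separates it from compound 2 and compound 3, is kept. The expectation therefore rests on the retained part, and no step beyond the scatter is anticipated; the estimated step is a number 5.6 percentage points lower from compound 1 to compound 4 (within the scatter). For compound 4 in this assay the expected value is 72%, with a range from 50% to 90%.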

Compound 4, a percentage reported as inhibition, at one concentration (the size of the read-out at that concentration, not a potency): 41.6%
For compound 4 the middle estimate is 30.4 percentage points above the measured one, and the stated range ends above it.
By their numbers in this assay, from the lowest: compounds 2 and 3 (each within the scatter of the next); then compound 4; then compound 1.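

The aryl end of the shared core is not a silent position in this assay: with the hydroxamic acid kept, trifluoromethyl in place of methoxy on the aromatic carbon gives a number 36 percentage points lower from compound 1 to compound 4 (beyond the scatter). For the compounds shown here, the earlier single-point step concerned only the amide-type nitrogen and stayed within the scatter, so this pair is the first to show that the number responds to a change at the 4-methoxyphenyl end. No measurement at hand accounts for this step.

A single pair does not separate what leaving methoxy contributes from what entering trifluoromethyl contributes. On these data alone, how a hydroxyl, a dimethylamino group or a chlorine on the same aromatic carbon would read in this assay remains open, as does whether the step carries over to other aryl groups on the core.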